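Propyl in place of a thiazolylmethyl arm: expected cytotoxicity

A few compounds are considered here, and "the series" means these few. Any claim that something is new, unique, unknown or untested is made for them only; others in the source may bear on it.

Measured so far in an ADME assay on BaF3 cells (Mus musculus) for cytotoxicity; a lower number here means that less compound is needed, a higher number that more compound is needed for the effect:
Compound 1, `CN1CCN(C(=O)c2cc3c(Nc4ccc(OC(F)(F)F)cc4)ncnc3s2)CC1`: 2690 nM
Compound 2, `Cc1nc(C)c(Cn2ncc3c(Nc4ccc(OC(F)(F)F)cc4)ncnc32)s1`: > 10000 nM, which is a limit of the assay and not a number
Compound 3, `O=C(NCCO)c1cc2c(Nc3ccc(OC(F)(F)F)cc3)ncnc2s1`: > 10000 nM, also a limit of the assay

Compound 2 therefore stands at the limit of > 10000 nM in this assay, at which 2 of the 3 values shown sit, together with compound 3, while compound 1 is the only one of the three with a number. Among the compounds with values here, the one measured step that joins two compounds differing in a single place runs from the carbonyl substituent of compound 1 to that of compound 3: an at least 3.7-fold higher number from compound 1 to compound 3 (0.57 log units; beyond the scatter). That step sits on a different part of the shared core and does not touch the group changed here.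

Compound 4, `CCCn1ncc2c(Nc3ccc(OC(F)(F)F)cc3)ncnc21`, arises from compound 2 by ethyl in place of 2,4-dimethyl-1,3-thiazol-5-yl on a saturated chain carbon bound to an aromatic nitrogen. Within the data shown here, no measured step covers this kind of change, and compound 2 itself sits at the limit, so the expectation rests on that limit alone.

Compound 4 is therefore expected to remain around 15000 nM, with a range from 4000 nM to 50000 nM. The estimated step that the limit leaves unreadable from compound 2 to compound 4 is expected to lie within the scatter, most likely with the assay again reporting only a limit.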

Compound 4, half-maximal effective concentration: 6600 nM
Compound 4: the middle estimate sits 2.3-fold (0.36 log units) above what was measured, and the stated range covers the measured number.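

With propyl as the arm, this position on the shared core now gives a real number in this assay, since compound 4 reads 6600 nM, so a small saturated chain here can bring the effect into the range the assay can count. Compound 2 gives > 10000 nM, which is a limit of the assay and not a number. The change from the (2,4-dimethyl-1,3-thiazol-5-yl)methyl arm to propyl comes out as an at least 1.5-fold lower number from compound 2 to compound 4 (0.18 log units; that floor lies within the scatter), so a real difference is not established, and its true size cannot be read because compound 2 carries only a limit: the limit of > 10000 nM in this assay, at which 2 of the 4 values shown sit.

Still open, on these data alone, is how the number at this position responds to other arms, such as a shorter methyl, a longer butyl chain, or a chain ending in an amine or a carboxylic acid. Compound 4 also differs from compound 1 and compound 3 in more than one place, so the carbonyl step between those two says nothing yet about this arm.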